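The source may hold more compounds than are shown below. What is called first, only, known or untested is meant among the compounds shown, and "the series" means these compounds.

Compound 1 `O=C(Nc1ccc(Cl)c(-c2nnc3c(Cl)cccn23)c1)c1cccc(Cl)c1` is an amide in which a 3-chlorophenyl group sits on the carbonyl carbon. Among the compounds with values here, in a functional assay on A549 cells (Homo sapiens) for antiproliferative activity, read by MTT assay, with a stated time of 72 h (a higher number here means a weaker inhibitor, a lower number a stronger inhibitor), compound 1 gives 52700 nM, the only plain number among the values shown, so it serves as the reference point. Compound 2 `O=C(Nc1ccc(Cl)c(-c2nnc3c(Cl)cccn23)c1)c1ccccc1Cl` carries 2-chlorophenyl in place of 3-chlorophenyl on the carbonyl carbon. In this assay compound 2 gives > 100000 nM, which is a limit of the assay rather than a number. Within the data shown here, the single measured step, an at least 1.8-fold higher number from compound 1 to compound 2 (0.27 log units; that floor lies within the scatter), therefore only tells where the chlorine may sit without weakening the inhibition further.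

Compound 3 `O=C(Nc1ccc(Cl)c(-c2nnc3c(Cl)cccn23)c1)c1cccnc1` differs from compound 1 by pyridin-3-yl in place of 3-chlorophenyl on a carbonyl carbon. Among the measured compounds shown here, no measured step covers an exchange of this kind, so the measured step gives no direct guide. For the measured compounds named here, what is known is that compound 1 is already a weak inhibitor and that its one measured neighbour reaches (the limit of > 100000 nM in this assay, at which 1 of the 2 values shown sits). A modest weakening beyond the scatter, or a step that ends at the limit, is expected. For compound 3 the expected value in this assay is 75000 nM, with a range from 30000 nM to 180000 nM. This corresponds to an expected step of a 1.4-fold higher number from compound 1 to compound 3 (0.15 log units; within the scatter).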

Compound 3, half-maximal inhibitory concentration: > 100000 nM
Compound 3: only a limit was reported; the forecaster's own chance of this, stated with the estimate: 40%; middle value at least 1.3-fold (0.12 log units) from the limit.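

In this assay, pyridin-3-yl in place of 3-chlorophenyl on the carbonyl carbon gives an at least 1.8-fold higher number from compound 1 to compound 3 (0.27 log units; that floor lies within the scatter). Compound 3 has only a limit of the assay, so this step is a floor: it neither sets the size of the change nor shows that the change goes beyond the scatter. The earlier pair only moved the chlorine around the phenyl ring, whereas this exchange removes the chlorine and brings in a ring nitrogen, and it too gives no plain number, which leaves compound 1 as the only compound with a measured value and shows that this position has not yet yielded a stronger inhibitor, with the readings now crowded at the top of the range: the limit of > 100000 nM in this assay, at which 2 of the 3 values shown sit.

The step between compound 2 and compound 3 cannot be read, as both are limits. Still open, on these data alone, is whether anything on this carbonyl carbon can bring the number clearly below that of compound 1, for example 4-chlorophenyl, plain phenyl, or a phenyl ring carrying an amine or a carboxylic acid.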